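Swapping chloro for methoxy on a shared core

A few compounds are considered here, and "the series" means these few. Any claim that something is new, unique, unknown or untested is made for them only; others in the source may bear on it.

Measured compounds:
- compound 1, `COc1cc2c(/C=C3/C(=O)Nc4ccc(Cl)cc43)c(Cl)n(Cc3cc(OC)c(OC)c(OC)c3)c2cc1C`, 3890 nM
- compound 2, `COc1ccc2c(c1)/C(=C\c1c(Cl)n(Cc3cc(OC)c(OC)c(OC)c3)c3cc(C)c(OC)cc13)C(=O)N2`, 95500 nM
- compound 3, `COc1c(/C=C2/C(=O)Nc3ccc(Cl)cc32)c2ccccc2n1-c1ccccc1`, 24000 nM

All three were tested in a functional assay on cells (Cancer cell lines, Homo sapiens) for cytotoxicity, with a stated time of 48 h; on this read-out lower numbers stand for stronger inhibition of growth and higher numbers for weaker inhibition of growth. Compound 1 gives 3890 nM, and compound 2 gives 95500 nM, so the change methoxy in place of chloro on an aromatic carbon brought a 25-fold higher number from compound 1 to compound 2 (1.39 log units; beyond the scatter). Compound 3 gives 24000 nM; the difference between its core and the core of compound 1 is not broken down here.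

Compound 4, `COc1ccc2c(c1)/C(=C\c1c(OC)n(-c3ccccc3)c3ccccc13)C(=O)N2`, has not yet been measured. It differs from compound 3 by methoxy in place of chloro on an aromatic carbon, the same change that leads from compound 1 to compound 2, made at the same place on the shared core. Because that change brought a 25-fold higher number from compound 1 to compound 2 (1.39 log units; beyond the scatter), a step of similar direction and size is expected from compound 3 to compound 4, about a 17-fold higher number from compound 3 to compound 4 (1.22 log units; beyond the scatter) in this assay. That expectation rests on a single pair, so its size is uncertain. Compound 4 is therefore estimated at 400000 nM, plausibly between 100000 nM and 1500000 nM.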

Compound 4, concentration for total growth inhibition: 13200 nM
For compound 4 the middle estimate is 30-fold (1.48 log units) above the measured one, and the stated range ends above it.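

In this assay, methoxy in place of chloro on an aromatic carbon gives a 1.8-fold lower number from compound 3 to compound 4 (0.26 log units; within the scatter), so on this core the swap leaves no difference that can be told from the usual scatter of repeated measurements. Set beside the large step on the other core, this shows that the effect of the change did not carry over from one core to the other: the same change on two cores in this assay, a 25-fold higher number (1.39 log units; beyond the scatter) from compound 1 to compound 2 and a 1.8-fold lower number (0.26 log units; within the scatter) from compound 3 to compound 4, 45-fold (1.65 log units) apart, beyond the scatter of two such steps

It does not show which part of the two cores decides the outcome, and two pairs give no rule for predicting the step on any further core in this series.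

The compounds shown leave open how other groups on this aromatic carbon, such as an amine or a carboxylic acid, would compare with chloro and methoxy on either core. They also leave open whether a third core would follow compound 1 and compound 2 or compound 3 and compound 4.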